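Aryl Swaps on a Shared Core Point Toward Compound 4

The source may report more compounds than this note shows. Statements on the series, on what has been measured and on what is new or still open speak of the compounds shown alone.

Three compounds built on one core, differing only in the aromatic group carried on a nitrogen of the five-membered ring, have been measured. In a functional assay on CHO-K1 cells with Glucose-dependent insulinotropic receptor (Homo sapiens) as the target, read by a luciferase reporter, with a stated time of 5 h (on this read-out lower numbers stand for smaller maximal responses and higher numbers for larger maximal responses), compound 1 `CC(C)OC(=O)N1CCC(Oc2ncnc3c2CCN3c2ccc(S(C)(=O)=O)cn2)CC1` gives 111%. In this assay compound 2 `CC(C)OC(=O)N1CCC(Oc2ncnc3c2CCN3c2ccc(C#N)cn2)CC1` gives 105%. In this assay compound 3 `CC(C)OC(=O)N1CCC(Oc2ncnc3c2CCN3c2ccc(S(C)(=O)=O)c(F)c2)CC1` gives 109%. Compound 3 thus stands second highest of the three numbers, nearest to compound 1 and furthest from compound 2, yet every step among them is within the scatter: a number 6 percentage points lower from compound 1 to compound 2 (within the scatter), a number 2 percentage points lower from compound 1 to compound 3 (within the scatter) and a number 4 percentage points higher from compound 2 to compound 3 (within the scatter).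

Compound 4 `CC(C)OC(=O)N1CCC(Oc2ncnc3c2CCN3c2ccc([S+]([O-])N(C)C)cc2)CC1` has not yet been measured. It differs from compound 3 in this way: a group of 11 heavy atoms (8 carbon, 1 nitrogen, 1 oxygen, 1 sulfur; one six-membered aromatic ring of carbon only) in place of a group of 11 heavy atoms (7 carbon, 2 oxygen, 1 fluorine, 1 sulfur; one six-membered aromatic ring of carbon only), on a nitrogen on an aromatic ring in a ring. Going by the values given here, the steps that bear on it are those that already exchanged the aromatic group on that same nitrogen, namely the move from compound 1 to compound 3 and from compound 2 to compound 3, and both stayed within the scatter. On that basis compound 4 is expected to show no step beyond the scatter in this assay, that is a number 3 percentage points lower from compound 3 to compound 4 (within the scatter). Compound 4 is therefore estimated at 106%, with a range from 92% to 120%.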

Compound 4, largest response reached (reported as percent of maximum), in percent of the reference or control that the assay uses: 128%
Estimate against measurement, compound 4: 22 percentage points below; the measured number lies above the stated range.
By their numbers in this assay, from the lowest: compounds 2, 3 and 1 (each within the scatter of the next); then compound 4.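

In this assay, going by these compounds alone, exchanging the aromatic group on the nitrogen of the five-membered non-aromatic ring had so far left the number within the scatter, so this position could have seemed indifferent to such swaps; the group carried by compound 4 changes that picture, with a number 19 percentage points higher from compound 3 to compound 4 (beyond the scatter), a number 17 percentage points higher from compound 1 to compound 4 (beyond the scatter) and a number 23 percentage points higher from compound 2 to compound 4 (beyond the scatter). The three earlier compounds remain within the scatter of one another, while compound 4 stands apart from all of them, showing that a change at this one position can lift the maximal response beyond the level reached with the methylsulfonyl and cyano aryl groups. Nothing at hand explains this rise.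

The step from compound 3 to compound 4 replaces the sulfur-bearing group and removes the fluorine together, so the compounds shown do not separate the contributions of these two changes. They also leave open whether a morpholine, a carboxylic acid or a longer alkyl chain in place of the sulfur-bearing group on the same carbon-only aromatic ring would hold the response at the level of compound 4.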